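Working notes: from compound 2 to compound 3

This account rests on a few compounds, and the source may have more. Where it says the series, first, only, none or still open, it means among the compounds named here.

- compound 1 `Cc1ccc(CO/N=C2/C(c3c[nH]c4ccc(Br)cc34)=Nc3ccc(Br)cc32)cc1`: 15100 nM
- compound 2 `FC(F)(F)c1ccc(CO/N=C2/C(c3c[nH]c4ccc(Br)cc34)=Nc3ccc(Br)cc32)cc1`: 12400 nM
- compound 3 `Clc1cccc(CO/N=C2/C(c3c[nH]c4ccc(Br)cc34)=Nc3ccc(Br)cc32)c1`: not yet measured

In a functional assay on SPCA2 cells (Homo sapiens) for cytotoxicity, read by MTT assay, with a stated time of 2 days (on this read-out lower numbers stand for stronger inhibition and higher numbers for weaker inhibition), compound 2 gives 12400 nM, within the scatter of compound 1 at 15100 nM, so the two cannot be ranked. The change to compound 3 is 3-chlorophenyl in place of 4-(trifluoromethyl)phenyl on a saturated chain carbon bound to an oxygen on an unsaturated carbon, with the same difference reading 4-(trifluoromethyl)benzyl to 3-chlorobenzyl. For the measured compounds named here, the one measured step bearing on this is a 1.2-fold lower number from compound 1 to compound 2 (0.09 log units; within the scatter), which swaps methyl for trifluoromethyl on the aromatic carbon of the same benzyl group. Going by the values given here, no measured compound carries a 3-chlorophenyl group, so this support is indirect. On that evidence, no step beyond the scatter is expected in this assay, in either direction. The estimate amounts to an expected 1.0-fold higher number from compound 2 to compound 3 (0.02 log units; within the scatter). Compound 3 is expected at 13000 nM, with an estimated range of 6000 nM to 28000 nM.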

Compound 3, half-maximal inhibitory concentration: 13500 nM
Estimate against measurement, compound 3: 1.0-fold (0.02 log units) below, within the range that was stated.
By their numbers in this assay, from the lowest: compounds 2, 3 and 1 (each within the scatter of the next).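

In this assay, 3-chlorophenyl in place of 4-(trifluoromethyl)phenyl gives a 1.1-fold higher number from compound 2 to compound 3 (0.04 log units; within the scatter), and 3-chlorophenyl in place of 4-methylphenyl gives a 1.1-fold lower number from compound 1 to compound 3 (0.05 log units; within the scatter). The earlier step changed only the group on the same aromatic carbon, whereas these steps change both the group and its place on the ring, as the names show, and neither leaves the scatter, so the three compounds cannot be ranked. No measurement is available that bears on why these changes leave the number within the scatter.

The compounds shown carry only methyl, trifluoromethyl and chlorine on this aromatic ring, all with numbers within the scatter of the next. On these data alone, whether an amine or a carboxylic acid on that ring, or a longer chain in place of the benzyl carbon, would give a step beyond the scatter remains open.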